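Working notes: cytotoxicity across three measured analogues

A few compounds are considered here, and "the series" means these few. Any claim that something is new, unique, unknown or untested is made for them only; others in the source may bear on it.

Measured so far:
- compound 1 `Cn1nnnc1SCC(=O)N/N=C/c1ccc(Br)cc1`: 10000000 nM
- compound 2 `Cn1nnnc1SCC(=O)N/N=C/c1ccc(O)cc1`: 632000 nM
- compound 3 `Cn1nnnc1SCC(=O)N/N=C/c1ccccc1Br`: 20000 nM

All numbers come from an ADME assay on NIH3T3 cells (Mus musculus) for cytotoxicity, read by XTT assay, with a stated time of 24 h; a higher number here means a weaker inhibitor, a lower number a stronger inhibitor. For the measured compounds named here, the single change from compound 1 to compound 2 is hydroxy in place of bromo on an aromatic carbon; it gave a 16-fold lower number from compound 1 to compound 2 (1.20 log units; beyond the scatter). Compound 3 holds the lowest number of the three, and its steps to compound 2 and to compound 1 both lie beyond the scatter. Compound 3 and compound 1 have the same atoms joined differently; the difference between the two cores is not broken down here.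

Compound 4 `Cn1nnnc1SCC(=O)N/N=C/c1ccccc1O` is not yet measured in this assay. It differs from compound 3 by hydroxy in place of bromo on an aromatic carbon. The place is not the same as before: in compound 2 the hydroxy sits para to a large group, in compound 4 it sits ortho to a large group, so this is the same kind of change, not the same.

In this assay a step of an 8.0-fold lower number from compound 3 to compound 4 (0.90 log units; beyond the scatter) is expected, beside the earlier 16-fold lower number from compound 1 to compound 2 (1.20 log units; beyond the scatter), resting on that step and on compound 3 at 20000 nM. Compound 4 is estimated at 2500 nM, between 500 nM and 15000 nM.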

Compound 4, half-maximal inhibitory concentration: > 10000000 nM
Compound 4 gave a limit, no number (the forecaster's own chance of this, stated with the estimate: 5%); at least 4000-fold (3.60 log units) between middle value and limit.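

In this assay the new step is an at least 500-fold higher number from compound 3 to compound 4 (2.69 log units; beyond the scatter), so hydroxy in place of bromo on an aromatic carbon does not carry over from one core to the other, neither in direction nor in size: the same change on two cores in this assay, a 16-fold lower number (1.20 log units; beyond the scatter) from compound 1 to compound 2 and an at least 500-fold higher number (2.69 log units; beyond the scatter) from compound 3 to compound 4, at least 7900-fold (3.89 log units) apart, beyond the scatter of two such steps

Compound 4 gives > 10000000 nM, which is a limit of the assay and not a number, so the step has a bound and no exact size: the limit of > 10000000 nM in this assay, at which 1 of the 4 values shown sits.

The two pairs also differ in where the change sits, and with one pair on each core the data cannot separate that place from any other difference between the cores, nor do they give a rule for further cores.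

The compounds shown leave open how an aromatic carbon carrying a group other than bromo or hydroxy, such as an amine or a carboxylic acid, would read in this assay. They also leave open whether a methoxy group in place of the hydroxy of compound 4 would stay at the limit.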